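Swapping a Carbon Ring for Fluorine in a Sulfonamide Series

The source may hold more compounds than are shown below. What is called first, only, known or untested is meant among the compounds shown, and "the series" means these compounds.

Compound 2, `CC(C)CCn1nc(CC2CCC2)c(O)c(C2=NS(=O)(=O)c3cc(NS(C)(=O)=O)ccc3N2)c1=O`, was examined in an in vitro ADME assay on microsomes from liver (Homo sapiens) for metabolic stability, tested at 5 uM (a higher number here means that the compound lasts longer, a lower number that the compound disappears faster), where compound 2 gives 0.417 h. Of the two compounds measured, compound 2 stands highest; the other, compound 1, `COCN(c1ccc2c(c1)S(=O)(=O)N=C(c1c(O)c(-c3cccs3)nn(CCC(C)C)c1=O)N2)S(C)(=O)=O`, gives 0.183 h in this assay, a gap that lies beyond the usual scatter of repeated measurements. Among the measured compounds shown here, no step between measured compounds that differ in one place has been recorded, so the change leading to compound 3, `CC(C)CCn1nc(CCC(F)(F)F)c(O)c(C2=NS(=O)(=O)c3cc(NS(C)(=O)=O)ccc3N2)c1=O`, has no measured neighbour to lean on. The change is 2,2,2-trifluoroethyl in place of cyclobutyl on a saturated chain carbon bound to an aromatic carbon. For the measured compounds named here, with only two measured numbers as background, the account expects a step of a 1.4-fold higher number from compound 2 to compound 3 (0.16 log units; within the scatter), a modest rise that may not clear the scatter. The half-life of compound 3 in this assay is therefore estimated at 0.6 h, within a range from 0.3 h to 1.2 h.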

Compound 3, half-life: 0.517 h
Beside the measured number, compound 3's estimate is 1.2-fold (0.06 log units) above it; low and high end bracket the measured number.
By their numbers in this assay, from the lowest: compound 1; then compounds 2 and 3 (each within the scatter of the next).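

At this place, on a saturated chain carbon bound to an aromatic carbon, the series now has its first comparison of compounds that differ in one place: in this assay, putting 2,2,2-trifluoroethyl in place of cyclobutyl gives a 1.2-fold higher number from compound 2 to compound 3 (0.09 log units; within the scatter). Read one bond further out as cyclobutylmethyl to 3,3,3-trifluoropropyl, the change shows that an open chain carrying fluorine can stand in for the four-membered carbon ring with no difference in half-life that can be told from the scatter. Nothing measured here explains this result.

The compounds shown leave open whether an amine, a carboxylic acid or a longer chain at this place would read differently from these two groups. They also leave open whether this exchange would read the same with other parts of the molecule altered.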